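The source may report more compounds than this note shows. Statements on the series, on what has been measured and on what is new or still open speak of the compounds shown alone.

Three compounds share one core and differ only in the aryl group carried on a saturated chain carbon bound to an aromatic carbon. In an assay on isolated protein for inhibition of Long-chain-fatty-acid--CoA ligase 1 (Mus musculus), read by mass spectrometry, with a stated time of 90 min, in the presence of a further agent that is not named here (on this read-out lower numbers stand for stronger inhibition and higher numbers for weaker inhibition), compound 1 `Cc1cccc(Cc2nc3cc(O[C@H]4CC[C@@H](C(=O)O)CC4)ccc3n2C)c1` gives 30 nM. In this assay compound 2 `Cc1ccccc1Cc1nc2cc(O[C@H]3CC[C@@H](C(=O)O)CC3)ccc2n1C` gives 5400 nM, and compound 3 `Cn1c(Cc2cccc(C(F)(F)F)c2)nc2cc(O[C@H]3CC[C@@H](C(=O)O)CC3)ccc21` gives 86 nM. Compound 3 thus stands second highest of the three numbers, nearest to compound 1 and furthest from compound 2.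

Compound 4 `Cn1c(Cc2ccc3c(c2)OCC3)nc2cc(O[C@H]3CC[C@@H](C(=O)O)CC3)ccc21` has not yet been measured. It differs from compound 3 in one place: a group of 9 heavy atoms (8 carbon, 1 oxygen; one five-membered non-aromatic ring with 1 hetero atom, one six-membered aromatic ring of carbon only) in place of a group of 10 heavy atoms (7 carbon, 3 fluorine; one six-membered aromatic ring of carbon only), on a saturated chain carbon bound to an aromatic carbon. For the measured compounds named here, no measured step exchanges a single phenyl for a fused two-ring group, so none bears on this change directly. The measured steps do show that the group at this place matters: exchanging 3-methylphenyl for 2-methylphenyl gave a 180-fold higher number from compound 1 to compound 2 (2.26 log units; beyond the scatter), exchanging 3-(trifluoromethyl)phenyl for 2-methylphenyl gave a 63-fold lower number from compound 2 to compound 3 (1.80 log units; beyond the scatter), while exchanging methyl for trifluoromethyl gave only a 2.9-fold higher number from compound 1 to compound 3 (0.46 log units; beyond the scatter). With a group of a new kind, the step is expected to be a 1.4-fold higher number from compound 3 to compound 4 (0.14 log units; within the scatter), with wide uncertainty in either direction. Compound 4 is expected to give about 120 nM in this assay, within a range from 20 nM to 800 nM.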

Compound 4, half-maximal inhibitory concentration: 36 nM
For compound 4 the middle estimate is 3.3-fold (0.52 log units) above the measured one; the range from low to high includes it.
By their numbers in this assay, from the lowest: compounds 1 and 4 (each within the scatter of the next); then compound 3; then compound 2.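

A fused two-ring group is accepted on the saturated chain carbon bound to an aromatic carbon: in place of 3-(trifluoromethyl)phenyl it brings a 2.4-fold lower number from compound 3 to compound 4 (0.38 log units; beyond the scatter) and in place of 2-methylphenyl it brings a 150-fold lower number from compound 2 to compound 4 (2.18 log units; beyond the scatter) on the same read-out. Set against 3-methylphenyl, the same kind of exchange gives a 1.2-fold higher number from compound 1 to compound 4 (0.08 log units; within the scatter) and stays within the scatter, so the fused group and 3-methylphenyl cannot be told apart here, and a second ring at this place does not by itself bring a high number. No measurement at hand explains why the fused group is accepted at this place.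

For the compounds shown here, it remains open whether the oxygen in the five-membered ring of compound 4 matters at all, as no compound here carries an amine nitrogen or a plain carbon in its place. Also open, as far as these compounds go, is how a phenyl group bearing an amine, a carboxylic acid or a longer chain would compare with the fused group and with 3-methylphenyl at this place.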